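Methyl for methoxycarbonyl: expected tolerance of compound 3

The compounds below may be only part of what the source reports. "The series", "measured", "known", "first", "only" and "open" are said of these compounds alone.

Compound 1 `O=c1c(CO)cc(-c2ccc(F)nc2F)nn1Cc1ccc(Cl)cc1`: > 100000 nM
Compound 2 `COC(=O)c1cc(-c2ccc(F)nc2F)nn(Cc2ccc(Cl)cc2)c1=O`: > 100000 nM

Among the measured compounds shown here, both values come from an ADME assay on HepG2 2.2.15 cells (Homo sapiens) for cytotoxicity, read by MTT assay, with a stated time of 8 days (a higher number here means that more compound is tolerated, a lower number that less compound is tolerated), and the series so far rests on (the limit of > 100000 nM in this assay, at which 2 of the 2 values shown sit). Compound 2 stands at > 100000 nM, which is a limit and not a number.

Compound 3 `Cc1cc(-c2ccc(F)nc2F)nn(Cc2ccc(Cl)cc2)c1=O` has methyl in place of methoxycarbonyl on an aromatic carbon. For the measured compounds named here, the one measured step at this place is a step that the two limits leave unreadable from compound 1 to compound 2, and it gives no size to carry over. Compound 1, with hydroxymethyl there, gives > 100000 nM, also a limit. No group tried at this place has yet brought a measurable value, so no step beyond the scatter is expected in this assay, and no direction can be assigned. The expected outcome is a number no higher from compound 2 to compound 3 (the limit leaves the size open). For compound 3 the estimated value is 100000 nM, with an expected range of 40000 nM to 200000 nM.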

Compound 3, half-maximal cytotoxic concentration: 83800 nM
Compound 3: the middle estimate sits 1.2-fold (0.08 log units) above what was measured, and the stated range covers the measured number.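

In this assay, among the compounds shown here, compound 3 gives 83800 nM as the first value at this aromatic carbon that is a number and not a limit, so methyl is the first group here to bring a readable value. Methyl in place of methoxycarbonyl gives an at least 1.1-fold lower number from compound 2 to compound 3 (0.07 log units; that floor lies within the scatter) and hydrogen in place of hydroxy on the saturated chain carbon gives an at least 1.1-fold lower number from compound 1 to compound 3 (0.07 log units; that floor lies within the scatter) as its counterpart, so neither step is shown to exceed the scatter. On these data alone, compound 2 stands at > 100000 nM as a limit and not a number, so the true size of the step from it stays open, and the step between compound 1 and compound 2 cannot be read.

As far as these compounds go, whether any group at this place moves the number beyond the scatter remains open. An amine, a carboxylic acid or a longer chain on this carbon would test that.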